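The source may hold more compounds than are shown below. What is called first, only, known or untested is meant among the compounds shown, and "the series" means these compounds.

Measured compounds:
- compound 1 `Cc1ccc(-n2c(-c3coc4cc(C)c(Cl)cc4c3=O)nc(-c3ccccc3)c2-c2ccccc2)c(C)c1` — in an ADME assay on MCF-10A cells (Homo sapiens) for cytotoxicity, read by MTT assay, with a stated time of 72 h (a higher number here means a weaker inhibitor, a lower number a stronger inhibitor), compound 1 has "not determined" (no result reported)
- compound 2 `COc1cccc(-n2c(-c3coc4cc(C)c(Cl)cc4c3=O)nc(-c3ccccc3)c2-c2ccccc2)c1` — compound 2 has "not determined" (no result reported)
- compound 3 `Cc1cc2occ(-c3nc(-c4ccccc4)c(-c4ccccc4)n3-c3ccc([N+](=O)[O-])cc3)c(=O)c2cc1Cl` — compound 3 gives > 100000 nM

The value of compound 3 is a limit of this assay, not a number; it is the only single result in the set, and it sits at the limit of > 100000 nM in this assay, at which 1 of the 3 values shown sits. Within the data shown here, compound 1 and compound 2 carry no result, so no step between measured compounds can be drawn and there is no measured pair to compare against.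

Compound 4 `Cc1cc2occ(-c3nc(-c4ccccc4)c(-c4ccccc4)n3-c3ccc(Cl)cc3)c(=O)c2cc1Cl` differs from compound 3 in one place: chloro in place of nitro on an aromatic carbon.

Among the measured compounds shown here, with compound 3 at the limit, no step of any size can be read from the data. The expectation for compound 4 is no step beyond the scatter, with the step from compound 3 to compound 4 estimated as a number no higher from compound 3 to compound 4 (the limit leaves the size open). Compound 4 is therefore expected at about 100000 nM in this assay, within a range from 30000 nM to 300000 nM, and it is likely that this assay again reports only a limit for compound 4 rather than a number.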

Compound 4, half-maximal inhibitory concentration: 92000 nM
Compound 4: middle estimate off by 1.1-fold (0.04 log units), on the high side; the range from low to high includes it.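

In this assay, among these compounds, chloro in place of nitro on the aromatic carbon para to a large group gives an at least 1.0-fold lower number from compound 3 to compound 4 (0.03 log units; that floor lies within the scatter), and compound 4 supplies the first actual number, 92000 nM. With this single pair, the 4-chlorophenyl compound shows that a numerical result can be obtained at this position, but it shows no step beyond the scatter. The size of the step stays open because the value of compound 3 is a limit rather than a number: the limit of > 100000 nM in this assay, at which 1 of the 4 values shown sits.

As far as these compounds go, it remains open how an amine or a carboxylic acid on the same aromatic carbon would read in this assay. Also open, from the compounds shown here alone, is whether a longer chain elsewhere on the shared core would give a value clearly apart from that of compound 4.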